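Replacing methylamino with 1-methoxyethyl on the shared core

The compounds below may be only part of what the source reports. "The series", "measured", "known", "first", "only" and "open" are said of these compounds alone.

Of the compounds shown here, three sharing a common core have been measured in an assay on T-REx-293 cells for inhibition of potassium channel subfamily T member 1 (Homo sapiens), read by patch clamp; a lower number here means a stronger inhibitor, a higher number a weaker inhibitor. Compound 1 `COc1cc(-c2noc([C@H](C)NC(=O)c3cc(C(F)(F)F)nn3C)n2)ccn1` gives 27 nM, compound 2 `C[C@H](NC(=O)c1cc(C(F)(F)F)nn1C)c1nc(-c2ccnc(C(F)F)c2)no1` gives 61 nM, and compound 3 `CNc1cc(-c2noc([C@H](C)NC(=O)c3cc(C(F)(F)F)nn3C)n2)ccn1` gives 195 nM. Compound 3 stands highest of the three; the step of a 7.2-fold higher number from compound 1 to compound 3 (0.86 log units; beyond the scatter) and the step of a 3.2-fold higher number from compound 2 to compound 3 (0.50 log units; beyond the scatter) both lie beyond the scatter, as does a 2.3-fold higher number from compound 1 to compound 2 (0.35 log units; beyond the scatter). Compound 4 `CO[C@@H](C)c1cc(-c2noc([C@H](C)NC(=O)c3cc(C(F)(F)F)nn3C)n2)ccn1` differs from compound 3 in one place: 1-methoxyethyl in place of methylamino on an aromatic carbon. Among the compounds with values here, no measured pair carries this exact exchange, so the two steps that bear on it are those leading into compound 3, where a methylamino group in place of methoxy or of difluoromethyl on the same aromatic carbon raised the number by a modest amount each time. Since the 1-methoxyethyl group, like those two groups, carries no hydrogen-bond donor, compound 4 is expected to move back down, by a 3.3-fold lower number from compound 3 to compound 4 (0.51 log units; beyond the scatter), toward the range of compounds 1 and 2. The estimate for compound 4 in this assay is 60 nM, with a range from 20 nM to 200 nM.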

Compound 4, half-maximal inhibitory concentration: 744 nM
Beside the measured number, compound 4's estimate is 12-fold (1.09 log units) below it, outside the stated range (above it).
By their numbers in this assay, from the lowest: compound 1; then compound 2; then compound 3; then compound 4.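

At this aromatic carbon, next to the ring nitrogen, the absence of a hydrogen-bond donor does not by itself keep the number low in this assay: 1-methoxyethyl in place of methylamino gives a 3.8-fold higher number from compound 3 to compound 4 (0.58 log units; beyond the scatter) and leaves compound 4 the weakest inhibitor of the four. The wider gaps, a 12-fold higher number from compound 2 to compound 4 (1.09 log units; beyond the scatter) and a 28-fold higher number from compound 1 to compound 4 (1.44 log units; beyond the scatter) and thus large in both cases, show that the position separates these groups strongly, with 1-methoxyethyl the least favourable of those compared. Nothing available here accounts for this rise. On these data alone, how the opposite configuration of the 1-methoxyethyl stereocentre would read remains open. So does whether a methoxymethyl or an ethyl group on the same carbon would fall nearer compound 1 or nearer compound 4.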